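Swapping a hydroxyphenyl for a dimethoxyphenyl on a cytotoxic core

The source may hold more compounds than are shown below. What is called first, only, known or untested is meant among the compounds shown, and "the series" means these compounds.

Measured so far:
compound 1 `COc1ccc(/C=C2\CCC/C(=C\c3ccc([N+](=O)[O-])cc3)C2=O)cc1` > 400000 nM
compound 2 `O=C1/C(=C/c2ccc(O)cc2)Cc2ccccc2/C1=C\c1ccc([N+](=O)[O-])cc1` 14000 nM
compound 3 `COc1ccc(/C=C2\CC/C(=C\c3ccc([N+](=O)[O-])cc3)C2=O)cc1` > 400000 nM

Of the compounds shown here, three have been tested in a functional assay on HSC-3 cells (Homo sapiens) for cytotoxicity; on this read-out lower numbers stand for higher toxicity in this test and higher numbers for lower toxicity in this test. Among the measured compounds shown here, compound 2 gives 14000 nM, and this is the only real number among the three. For compound 1 the assay reports only a limit, > 400000 nM. For compound 3 the assay likewise reports only a limit, > 400000 nM. So compound 2 stands alone as the one compound with a measurable concentration, while the other two sit at the limit of > 400000 nM in this assay, at which 2 of the 3 values shown sit. Compounds 1 and 3 are built on cores that differ from that of compound 2, so no single change links them to it, and nothing can be said about the cause of their limits.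

The next compound, compound 4 `COc1ccc(/C=C2\Cc3ccccc3/C(=C\c3ccc([N+](=O)[O-])cc3)C2=O)cc1OC`, keeps the core of compound 2 and changes one group: 3,4-dimethoxyphenyl in place of 4-hydroxyphenyl on a double-bonded chain carbon bound to a double-bonded ring carbon. The hydrogen-bond donor of the 4-hydroxyphenyl is lost and two methoxy groups arrive instead.

For the measured compounds named here, no measured step of this kind exists here, so the expectation rests on little. Compound 4 is expected to lose toxicity, with a step of a 7.1-fold higher number from compound 2 to compound 4 (0.85 log units; beyond the scatter) in this assay that is estimated to reach beyond the usual scatter. Compound 4 is therefore estimated at 100000 nM, within a range from 20000 nM to 400000 nM.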

Compound 4, half-maximal cytotoxic concentration: 4200 nM
Beside the measured number, compound 4's estimate is 24-fold (1.38 log units) above it, outside the stated range (below it).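

In this assay, the exchange on the shared core gives a 3.3-fold lower number from compound 2 to compound 4 (0.52 log units; beyond the scatter), so compound 4 is somewhat more toxic to these cells than compound 2. Among the compounds shown here, this is the first comparison of compounds that differ in one place, and it shows that this position, on a double-bonded chain carbon bound to a double-bonded ring carbon, accepts the larger 3,4-dimethoxyphenyl and that losing the hydrogen-bond donor of the 4-hydroxyphenyl does not cost toxicity in this pair. Nothing measured here tells why the number moves in this direction.

Going by these compounds, the loss of the hydroxyl and the arrival of two methoxy groups come as one change, so their separate shares remain open, and a 4-methoxyphenyl or a 4-aminophenyl at this position would be needed to pull them apart. On these data alone, compounds 1 and 3 carry other cores and give only limits of the assay, so any step to them cannot be read, and whether the exchange would act the same way on those cores stays unknown: the limit of > 400000 nM in this assay, at which 2 of the 4 values shown sit.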